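The compounds below may be only part of what the source reports. "The series", "measured", "known", "first", "only" and "open" are said of these compounds alone.

Measured so far:
- compound 1, `c1ccc(CN(CCCCN(C[C@H]2Cc3ccccc3CN2)[C@H]2CCCc3cccnc32)Cc2ccccc2)cc1`: > 16700 nM
- compound 2, `c1ccc2c(c1)CN[C@@H](CN(CCCCNCC1CCSCC1)[C@H]1CCCc3cccnc31)C2`: 69.6 nM

In a functional assay on cells for antagonist activity at C-X-C chemokine receptor type 4 (Homo sapiens), read by fluorescence and calcium flux, with stated times of 25 min and 90 s (on this read-out lower numbers stand for stronger inhibition and higher numbers for weaker inhibition), compound 2 gives 69.6 nM, and this is the only plain number among the two results shown. For the measured compounds named here, the entry for compound 1 is a limit of the assay rather than a number, (the limit of > 16700 nM in this assay, at which 1 of the 2 values shown sits), so it cannot be set against compound 2 as a measured step, and no pair of measured compounds here differs in just one place.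

Compound 3, `CC(C)(N)CCCN(C[C@H]1Cc2ccccc2CN1)[C@H]1CCCc2cccnc21`, has not yet been tested. It differs from compound 2 as follows: a group of 4 heavy atoms (3 carbon, 1 nitrogen; no ring) in place of a group of 9 heavy atoms (7 carbon, 1 nitrogen, 1 sulfur; one six-membered non-aromatic ring with 1 hetero atom), on a saturated chain carbon, three bonds along the chain from an amine nitrogen. Going by the values given here, with no measured step of this kind to lean on, the step from compound 2 to compound 3 is expected to be small, close to the scatter of the assay, and in no firm direction: a 1.6-fold higher number from compound 2 to compound 3 (0.20 log units; within the scatter). Compound 3 is therefore expected to come out at about 110 nM, within a range from 25 nM to 600 nM.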

Compound 3, half-maximal inhibitory concentration: 24.6 nM
Compound 3: the middle estimate sits 4.5-fold (0.65 log units) above what was measured, outside the stated range (below it).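

In this assay, for the compounds shown here, putting 1-amino-1-methylethyl in place of the group with the six-membered non-aromatic ring, on a saturated chain carbon, three bonds along the chain from an amine nitrogen, gives a 2.8-fold lower number from compound 2 to compound 3 (0.45 log units; beyond the scatter), which is the first step that can be read at this position. It shows that the ring and its sulfur are not needed here for inhibition in this test, since a group with no ring and fewer heavy atoms gives the lower number. Nothing shown here explains why the step goes in this direction.

This single step cannot separate the part played by the amine of the new group from that of its carbons. As far as these compounds go, how a hydroxyl, a carboxylic acid or a longer chain would fare at this same place remains open.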